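The compounds below may be only part of what the source reports. "The series", "measured", "known", "first", "only" and "open" are said of these compounds alone.

Measured compounds in a functional assay (trachea) with Cavia porcellus as the target; on this read-out lower numbers stand for an effect already at smaller amounts and higher numbers for an effect only at larger amounts of compound:
- compound 1 `CCCn1c(=O)n(CCC(C)=O)c(=O)c2[nH]cnc21` gives 3500 nM
- compound 2 `CCCn1c(=O)n(CCCCC(C)=O)c(=O)c2[nH]cnc21` gives 60 nM
- compound 3 `CCCn1cnc2c1c(=O)n(C)c(=O)n2CCC` gives 5000 nM

Compound 3 carries the highest number of the three; the gap to compound 1 is within the scatter, whereas compound 2 sits far lower, so only compound 2 is clearly separated from compound 3. For the measured compounds named here, the single step with a measured pair, a 58-fold lower number from compound 1 to compound 2 (1.77 log units; beyond the scatter), shows that lengthening the ketone-bearing chain on the shared core shifts the number strongly.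

Compound 4 `CCCn1c(=O)n(C)c(=O)c2c1ncn2CC(C)=O` differs from compound 3 as follows: acetyl in place of ethyl on a saturated chain carbon bound to an aromatic nitrogen. This change sits at a different nitrogen of the shared core than the chain varied between compound 1 and compound 2, and it introduces a short ketone-bearing chain rather than lengthening one, so the measured step bears on it only loosely. Compound 1, which also carries a short ketone chain, gives 3500 nM, a number close to compound 3. The expectation for compound 4 is therefore no step beyond the scatter, a 1.4-fold lower number from compound 3 to compound 4 (0.15 log units; within the scatter). The estimated value for compound 4 in this assay is 3500 nM, with a range from 800 nM to 15000 nM.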

Compound 4, half-maximal effective concentration: 1900 nM
Compound 4: the middle estimate sits 1.8-fold (0.27 log units) above what was measured, and the stated range covers the measured number.
By their numbers in this assay, from the lowest: compound 2; then compounds 4, 1 and 3 (each within the scatter of the next, the first and the last beyond it).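

In this assay, acetyl in place of ethyl on a saturated chain carbon bound to an aromatic nitrogen gives a 2.6-fold lower number from compound 3 to compound 4 (0.42 log units; beyond the scatter), a modest step but one that lies beyond the scatter. Read as propyl to 2-oxopropyl, the change shows that a carbonyl on this short chain moves the number at this position, while the earlier measured step concerned chain length elsewhere on the shared core. No measured evidence on the origin of this step is at hand.

Still open, on these data alone, is whether a longer ketone-bearing chain at this position would move the number further, as 2-acetylethyl in place of acetyl did at the other site. Also open, as far as these compounds go, is how a hydroxyl, an amine or a carboxylic acid on this chain would compare with the ketone.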